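Removing a Methyl from Nitrogen in Compound 1

The source may hold more compounds than are shown below. What is called first, only, known or untested is meant among the compounds shown, and "the series" means these compounds.

Measured in a functional assay on HMEC-1 cells (Homo sapiens) for inhibition, read by cell counting, with a stated time of 4 days; on this read-out lower numbers stand for stronger inhibition and higher numbers for weaker inhibition:
Compound 1 `COc1ccc(N(C)c2nc(C)nc3c2nc(C)n3C)cc1`: 7300 nM
Compound 2 `COc1ccc(N(C)c2ncnc3c2nc(C)n3C)cc1`: >= 100000 nM (a limit of the assay)
Compound 3 `COc1ccc(N(C)c2nc(C)nc3c2ncn3C)cc1`: 9200 nM

Compound 1 shares the low end of these numbers with compound 3, the two lying within the scatter of each other. Compound 4 `COc1ccc(N(C)c2nc(C)nc3[nH]c(C)nc23)cc1` carries hydrogen in place of methyl on an aromatic nitrogen of the core of compound 1 (hydrogen in place of methyl on an aromatic nitrogen). Within the data shown here, no measured step touches that nitrogen. The two nearest steps exchange methyl on an aromatic carbon, one giving an at least 13-fold higher number from compound 1 to compound 2 (1.13 log units; beyond the scatter) and the other 1.3-fold higher number from compound 1 to compound 3 (0.10 log units; within the scatter). Losing a methyl can thus cost much or nothing, and a moderate loss of inhibition is expected. The estimated step is a 3.4-fold higher number from compound 1 to compound 4 (0.53 log units; beyond the scatter). The expected value for compound 4 is 25000 nM, with an estimated range of 7000 nM to 100000 nM.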

Compound 4, half-maximal inhibitory concentration: 7100 nM
Beside the measured number, compound 4's estimate is 3.5-fold (0.55 log units) above it; the range from low to high includes it.
By their numbers in this assay, from the lowest: compounds 4, 1 and 3 (each within the scatter of the next). At a limit, above all of these: compound 2.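

In this assay, the methyl on the aromatic nitrogen of the five-membered aromatic ring can be replaced by hydrogen without a change beyond the scatter, the step being a 1.0-fold lower number from compound 1 to compound 4 (0.01 log units; within the scatter). Among these compounds, this is the first reading at this nitrogen, and it shows that inhibition at this level does not depend on the methyl there. Of the methyl removals shown, only the one leading to compound 2 costs inhibition beyond the scatter.

On these data alone, whether an ethyl, a longer chain or an amine on this nitrogen would keep that inhibition remains open. Nothing shown gives a reason for this result.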